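The source may report more compounds than this note shows. Statements on the series, on what has been measured and on what is new or still open speak of the compounds shown alone.

Working notes on a series with a shared core. In an in vitro functional assay on cells for antagonist activity at B1 bradykinin receptor (Homo sapiens), read by luminescence and calcium flux, with a stated time of 2 h (on this read-out higher numbers stand for weaker inhibition and lower numbers for stronger inhibition), compound 1 `Cc1ccc(S(=O)(=O)N2C=CNC(=O)[C@H]2CC(=O)N[C@@H]2CCc3ccccc32)cc1` gives 94.7 nM. Compound 2 `Cc1ccc(S(=O)(=O)N2C=CNC(=O)[C@H]2CC(=O)NC2CCC(C)CC2)cc1` gives 314 nM in this assay, the step being a 3.3-fold higher number from compound 1 to compound 2 (0.52 log units; beyond the scatter). Compound 3 `Cc1ccc(S(=O)(=O)N2C=CNC(=O)[C@H]2CC(=O)N[C@H]2CCN(C)CC2(C)C)cc1` gives 0.42 nM in this assay, the lowest number of the three measured; the steps of a 230-fold lower number from compound 1 to compound 3 (2.35 log units; beyond the scatter) and a 750-fold lower number from compound 2 to compound 3 (2.87 log units; beyond the scatter) are both large, and both exchange the whole group on the amide-type nitrogen.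

Compound 4 `CCN1CC[C@H](NC(=O)C[C@@H]2C(=O)NC=CN2S(=O)(=O)c2ccc(C)cc2)C(C)(C)C1` is to be measured in this assay. It differs from compound 3 in one place: methyl in place of hydrogen on a saturated chain carbon bound to an amine nitrogen in a ring. Cut one bond further out, the same difference reads methyl to ethyl. Going by the values given here, none of the measured steps bears on this change: each of them replaces the group on the amide-type nitrogen, whereas compound 4 keeps that group as in compound 3 and alters only the substituent on the ring amine nitrogen. Among the compounds with values here, no measured step therefore gives a size for the move from compound 3 to compound 4, and the expectation is a step not beyond the scatter, in neither direction with confidence. Compound 4 is expected to give 0.5 nM in this assay, with a range from 0.15 nM to 1.8 nM. The step thus estimated is a 1.2-fold higher number from compound 3 to compound 4 (0.08 log units; within the scatter), expected to lie within the scatter.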

Compound 4, half-maximal inhibitory concentration: 0.63 nM
Compound 4: the middle estimate sits 1.3-fold (0.10 log units) below what was measured, within the range that was stated.
By their numbers in this assay, from the lowest: compounds 3 and 4 (each within the scatter of the next); then compound 1; then compound 2.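

In this assay, going by these compounds alone, methyl in place of hydrogen on a saturated chain carbon bound to an amine nitrogen in a ring, which reads methyl to ethyl one bond further out, gives a step within the scatter (a 1.5-fold higher number from compound 3 to compound 4 (0.18 log units; within the scatter)), so this is the first change at the ring amine substituent and it leaves the number indistinguishable from that of compound 3. The large separation from the other amide-nitrogen groups also holds with the ethyl group in place (a 500-fold lower number from compound 2 to compound 4 (2.70 log units; beyond the scatter); a 150-fold lower number from compound 1 to compound 4 (2.18 log units; beyond the scatter)), so it no longer rests on compound 3 alone. No measurement accompanies these values that would explain the outcome at this position.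

Still open, going by these compounds, is how far the substituent on the ring amine nitrogen can be extended or altered, for example to a propyl or longer chain, a cyclopropyl group or a hydroxyethyl chain, and whether the plain amine with hydrogen on that nitrogen reads the same. Also open, on these data alone, is the part played by the ring amine nitrogen itself, which an acetyl group on that nitrogen or an oxygen atom in its place would begin to address.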